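Removing a Methyl Group From an Arginase Binder

This account rests on a few compounds, and the source may have more. Where it says the series, first, only, none or still open, it means among the compounds named here.

Of the compounds shown here, two have been tested in an assay for inhibition of arginase-1 (Homo sapiens), read by scintillation counting, with a stated time of 5 min, tested at 200 uM; on this read-out higher numbers stand for more inhibition at the one concentration tested (going by the name of the read-out) and lower numbers for less inhibition. Compound 1 `Cc1cc(=O)c(O)c(C(=O)O)o1` gives 8%. Compound 2 `Cc1occ(O)c(=O)c1C(=O)O` gives 5%, a number within the usual scatter of that of compound 1, so the two cannot be told apart. Compound 3 `O=C(O)c1occc(=O)c1O` awaits measurement in this assay. It differs from compound 1 by hydrogen in place of methyl on an aromatic carbon. Among the compounds with values here, no measured pair shows a comparable step, and both measured numbers sit close to the bottom of the scale, so no change beyond the scatter is expected. Compound 3 is estimated at 7%, with a range from 0% to 18%. The expected step is a number 1 percentage points lower from compound 1 to compound 3 (within the scatter).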

Compound 3, a percentage reported as inhibition, at one concentration (the size of the read-out at that concentration, not a potency): 1%
For compound 3 the middle estimate is 6 percentage points above the measured one; the range from low to high includes it.
By their numbers in this assay, from the lowest: compounds 3, 2 and 1 (each within the scatter of the next).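

In this assay, replacing methyl with hydrogen on the aromatic carbon next to the ring oxygen gives a number 7 percentage points lower from compound 1 to compound 3 (within the scatter), so compound 1 and compound 3 cannot be told apart. The methyl group is therefore not shown to matter here, although readings this close to the bottom of the scale leave little room to see a loss. No other measurement is available to explain this result.

As far as these compounds go, whether a longer chain or an amine at this position would lift inhibition clear of the scatter remains open.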